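The compounds below may be only part of what the source reports. "The series", "measured", "known", "first", "only" and "open" are said of these compounds alone.

Measured so far:
compound 1 `COc1cc(-c2cc(/C=C/C(=O)c3ccc(N)cc3)[nH]n2)cc(OC)c1OC` — 92%
compound 2 `COc1ccc(C(=O)/C=C/c2cc(-c3cc(OC)c(OC)c(OC)c3)n[nH]2)cc1` — 102%

Within the data shown here, in a functional assay on HOP-62 cells (Homo sapiens) for cytotoxicity, read by sulforhodamine B assay, with a stated time of 48 h, tested at 0.1 uM (on this read-out lower numbers stand for a stronger effect and higher numbers for a weaker effect at the one concentration tested), compound 2 gives the highest of the two numbers, but its only neighbour is compound 1, and the step of a number 10 percentage points higher from compound 1 to compound 2 (within the scatter) lies within the scatter, so the two values carry no order between them; both sit near the no-effect level.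

Compound 3 `COc1cc(-c2cc(/C=C/C(=O)c3ccc(F)c(F)c3)[nH]n2)cc(OC)c1OC` differs from compound 2 by 3,4-difluorophenyl in place of 4-methoxyphenyl on a carbonyl carbon. Among the measured compounds shown here, no measured step changes this group: the single step known, a number 10 percentage points higher from compound 1 to compound 2 (within the scatter), alters a different group and stays within the scatter. There is thus nothing in the series pointing to a shift beyond the scatter, and the values of compound 1 and compound 2 both give a baseline near full activity.

Compound 3 is estimated at 95%, with a range from 75% to 108%. The step of a number 7 percentage points lower from compound 2 to compound 3 (within the scatter) is accordingly expected to remain within the scatter.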

Compound 3, a percentage reported as activity, at one concentration (the size of the read-out at that concentration, not a potency): 101%
For compound 3 the middle estimate is 6 percentage points below the measured one; the measured number falls inside the stated range.
By their numbers in this assay, from the lowest: compounds 1, 3 and 2 (each within the scatter of the next).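

In this assay, 3,4-difluorophenyl on the carbonyl carbon stays within the scatter of both earlier groups: against 4-methoxyphenyl (with a number 1 percentage points lower from compound 2 to compound 3 (within the scatter)) and against 4-aminophenyl (with a number 9 percentage points higher from compound 1 to compound 3 (within the scatter)). Among these compounds, the earlier compounds compared only two groups at this carbon, both with a heteroatom attached to the ring; the third group carries two fluorines instead and has no hydrogen-bond acceptor, yet the three numbers still cannot be ordered and all remain near the no-effect level. No measurement offered here accounts for these values.

The compounds shown leave open whether any group on this carbonyl carbon moves the number beyond the scatter, for instance a carboxylic acid or a longer alkyl chain in place of the aromatic ring. On these data alone, it also remains open whether these three aromatic groups would separate at a higher concentration.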